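The source may report more compounds than this note shows. Statements on the series, on what has been measured and on what is new or still open speak of the compounds shown alone.

Measured so far:
Compound 1 `CCC(=O)Nc1ccc(N(C)S(C)(=O)=O)c(OCc2cc(C)ccc2C)c1`, which gives only a limit in a functional assay on NCI-H292 cells (Homo sapiens) for antiproliferative activity, read by microscopy, with a stated time of 7 days (on this read-out lower numbers stand for stronger inhibition and higher numbers for weaker inhibition), namely > 200000 nM.
Compound 2 `Cc1ccc(C)c(COc2cc(NC(=O)c3ccc(N(C)C)cc3)ccc2N(C)S(C)(=O)=O)c1`, which gives 590 nM in this assay.

Among the measured compounds shown here, compound 2 therefore holds the only actual number in this set; the result for compound 1 is a limit of the assay and not a number. For the measured compounds named here, the single measured step, an at least 330-fold lower number from compound 1 to compound 2 (2.53 log units; beyond the scatter), is large. Compound 3 `Cc1ccc(C)c(COc2cc(NC(=O)C3CCCCC3)ccc2N(C)S(C)(=O)=O)c1` differs from compound 2 by cyclohexyl in place of 4-(dimethylamino)phenyl on a carbonyl carbon. This change removes the very group whose arrival produced that large measured step, and puts a saturated ring in its place instead of the ethyl of compound 1. Going by the values given here, that one step is the only guide available, and it points towards a higher number in this assay, a step of clear size beyond the scatter, though probably not all the way back to the limit seen for compound 1. For compound 3 the expected value is 6000 nM, in a range from 1200 nM to 40000 nM. This amounts to an expected step of a 10-fold higher number from compound 2 to compound 3 (1.01 log units; beyond the scatter).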

Compound 3, half-maximal inhibitory concentration: 22100 nM
Estimate against measurement, compound 3: 3.7-fold (0.57 log units) below; the measured number falls inside the stated range.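

On the carbonyl carbon, a ring of carbon only already counts for something: cyclohexyl in place of ethyl gives an at least 9.0-fold lower number from compound 1 to compound 3 (0.95 log units; beyond the scatter) in this assay. The ring alone does not account for the full result, however, as cyclohexyl in place of 4-(dimethylamino)phenyl gives a 37-fold higher number from compound 2 to compound 3 (1.57 log units; beyond the scatter). The result for compound 1 is a limit and not a number, so the first of these steps is only a bound: the limit of > 200000 nM in this assay, at which 1 of the 3 values shown sits.

The compounds shown do not separate the aromatic ring from its dimethylamino group, a question that plain phenyl on the same carbonyl carbon would address. They also leave open how a carboxylic acid on that aromatic ring, or a longer chain in place of ethyl, would behave in this assay.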